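From Compound 3 to Compound 4 at an Assay Limit

The source may hold more compounds than are shown below. What is called first, only, known or untested is meant among the compounds shown, and "the series" means these compounds.

In an ADME assay on MT4 cells (Homo sapiens) for cytotoxicity, read by XTT assay, with a stated time of 5 days (on this read-out higher numbers stand for lower toxicity in this test and lower numbers for higher toxicity in this test), compound 1 (`COC(=O)N[C@H](C(=O)NN(CC[C@@](O)(Cc1ccccc1)C(=O)N[C@H]1c2ccccc2C[C@H]1O)Cc1ccc(-c2ccccn2)cc1)C(C)(C)C`) gives > 10000 nM as a limit, not a number. Compound 2 (`COC(=O)N[C@H](C(=O)NN(CC[C@@](O)(Cc1ccccc1)C(=O)N[C@H]1c2ccccc2C[C@H]1O)Cc1ccc(-c2cc(F)cc(F)c2)cc1)C(C)(C)C`) gives > 10000 nM as a limit too. Compound 3 (`COC(=O)N[C@H](C(=O)NN(CC[C@@](O)(Cc1ccccc1)C(=O)N[C@H]1c2ccccc2C[C@H]1O)Cc1ccc(-c2ccc(NC(C)=O)cc2)cc1)C(C)(C)C`) stands at > 10000 nM as a limit as well, so it has no exact number. Compound 4 (`COC(=O)N[C@H](C(=O)NN(CC[C@@](O)(Cc1ccccc1)C(=O)N[C@H]1c2ccccc2C[C@H]1O)Cc1ccc(-c2cnn(C)c2)cc1)C(C)(C)C`) differs from compound 3 in one place, on an aromatic carbon para to a large group (1-methyl-1H-pyrazol-4-yl in place of 4-acetamidophenyl on an aromatic carbon). Three measured swaps at that place bear on it: a step that the two limits leave unreadable from compound 1 to compound 2 and a step that the two limits leave unreadable from compound 1 to compound 3 and also a step that the two limits leave unreadable from compound 2 to compound 3 in turn, so none has a known size. These compounds share the limit of > 10000 nM in this assay, at which 3 of the 3 values shown sit, and nothing more. In this assay no step beyond the usual scatter is therefore expected in either direction, and the estimated step is a step that the limit leaves unreadable from compound 3 to compound 4 for now. Compound 4 is expected near 15000 nM with a range from 8000 nM to 50000 nM as the estimate.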

Compound 4, half-maximal cytotoxic concentration: > 10000 nM
Compound 4: no number, only a limit (the forecaster's own chance of this, stated with the estimate: 90%); the middle value does not contradict the limit.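

No step can be read between compound 4 and compound 1, compound 2 or compound 3, because all four stand at one assay limit and give no exact number: the limit of > 10000 nM in this assay, at which 4 of the 4 values shown sit.

The compounds shown leave open whether these four differ at all in this assay.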